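This account rests on a few compounds, and the source may have more. Where it says the series, first, only, none or still open, it means among the compounds named here.

Compound 1 `CC1=C(C(=O)Nc2ccc(Br)cc2)C(c2ccc(Cl)cc2Cl)N=C(SCc2ccc(F)cc2)N1` gives 22.7% in a functional assay on the whole organism (artery, strain albino) with Rattus norvegicus as the target, with a stated time of 120 min, at a dose of 10 mg/kg by the oral route; on this read-out lower numbers stand for less inhibition and higher numbers for more inhibition at the one dose given (going by the name of the read-out).
Compound 2 `COc1ccc(C2N=C(SCc3ccccc3Cl)NC(C)=C2C(=O)Nc2ccc(Br)cc2)cc1` gives 8.2%.
Compound 3 `COc1ccc(C2N=C(SCc3ccc(Cl)cc3)NC(C)=C2C(=O)Nc2ccc(Br)cc2)cc1` gives 16.5%.

Compound 3 stands second of the three numbers, yet its gaps to compound 1 and to compound 2 both fall within the usual scatter, so the three measured compounds cannot be told apart on this read-out. Among the measured compounds shown here, the only single-point step among them, a number 8.3 percentage points higher from compound 2 to compound 3 (within the scatter), is itself within the scatter.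

Compound 4 `COc1ccc(C2N=C(SCc3ccc(F)cc3)NC(C)=C2C(=O)Nc2ccc(Br)cc2)cc1` differs from compound 3 in one place: fluoro in place of chloro on an aromatic carbon. For the measured compounds named here, no measured step exchanges these two halogens directly. Compound 1 carries the (4-fluorobenzyl)sulfanyl group but differs from compound 3 in a second place as well; in this assay compound 1 gives 22.7%. Compound 3 gives 16.5%, and the two values lie within the scatter of each other. Nothing in the data therefore points to a shift beyond the scatter in this assay.

Compound 4 is expected to give 18%, between 5% and 32%, a step of a number 1.5 percentage points higher from compound 3 to compound 4 (within the scatter) that is estimated to stay within the scatter.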

Compound 4, a percentage reported as inhibition, in the whole organism at one dose (the size of the read-out at that dose, not a potency): 12.9%
The estimate for compound 4 lay 5.1 percentage points above the measured number; low and high end bracket the measured number.
By their numbers in this assay, from the lowest: compounds 2, 4, 3 and 1 (each within the scatter of the next, the first and the last beyond it).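

In this assay, among the compounds shown here, the first direct exchange of the two halogens, a number 3.6 percentage points lower from compound 3 to compound 4 (within the scatter), shows that chloro and fluoro cannot be told apart at this place on the aromatic ring. Two further single-place comparisons do not separate their pairs either: a number 4.7 percentage points higher from compound 2 to compound 4 (within the scatter), with 4-fluorophenyl in place of 2-chlorophenyl on the saturated chain carbon bound to sulfur, and a number 9.8 percentage points lower from compound 1 to compound 4 (within the scatter), with 4-methoxyphenyl in place of 2,4-dichlorophenyl on the saturated ring carbon. Nothing at hand offers an explanation for the size of these steps.

The compounds shown carry only halogens on this benzyl ring, so it stays open whether an amine or a carboxylic acid there would give a step beyond the scatter. The same question stands for a longer chain in place of the 4-fluorobenzyl group.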